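This account rests on a few compounds, and the source may have more. Where it says the series, first, only, none or still open, it means among the compounds named here.

Three esters built on the same bicyclic core have been measured in an ADME assay on a cell-free system (plasma, Homo sapiens) for metabolic stability, with Plasma (Rattus norvegicus) as the target, read by HPLC, at pH 7.4; on this read-out higher numbers stand for a longer-lived compound and lower numbers for a shorter-lived compound. Compound 1 `CC(=O)Oc1ccccc1C(=O)O[C@H]1CO[C@H]2[C@@H]1OC[C@H]2OC(=O)c1ccccc1O` gives 0.019 h, compound 2 `CC(=O)Oc1ccccc1C(=O)O[C@H]1CO[C@H]2[C@@H]1OC[C@H]2OC(=O)c1ccnn1C` gives 0.0642 h, and compound 3 `CC(=O)Oc1ccccc1C(=O)O[C@H]1CO[C@H]2[C@@H]1OC[C@H]2OC(=O)c1ccc(O)cc1` gives 0.0198 h. Compound 2 thus stands highest of the three: it lies a 3.4-fold higher number from compound 1 to compound 2 (0.53 log units; beyond the scatter), and a 3.2-fold lower number from compound 2 to compound 3 (0.51 log units; beyond the scatter) describes the return to compound 3, while the step of a 1.0-fold higher number from compound 1 to compound 3 (0.02 log units; within the scatter) leaves compound 1 and compound 3 indistinguishable.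

Compound 4 `CCCCC(=O)O[C@@H]1CO[C@H]2[C@@H]1OC[C@@H]2OC(=O)c1ccccc1OC(C)=O` is not yet measured. It differs from compound 2 by butyl in place of 1-methyl-1H-pyrazol-5-yl on a carbonyl carbon. Within the data shown here, neither measured step involves a chain in place of an aromatic group, so the only guidance is that moving away from the 1-methyl-1H-pyrazol-5-yl group, whether to a 2-hydroxyphenyl or a 4-hydroxyphenyl group, brought a modest fall beyond the scatter in each case. A butyl group is a further departure from compound 2, and the expectation is therefore a modest decrease in this assay, with a wide uncertainty because no aliphatic ester has been seen here; the estimated step is a 2.1-fold lower number from compound 2 to compound 4 (0.33 log units; beyond the scatter). Compound 4 is estimated at 0.03 h, with a plausible range from 0.01 h to 0.1 h.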

Compound 4, half-life: 0.0117 h
The estimate for compound 4 lay 2.6-fold (0.41 log units) above the measured number; measured number inside the range.
By their numbers in this assay, from the lowest: compounds 4, 1 and 3 (each within the scatter of the next); then compound 2.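

At this position on a carbonyl carbon, a butyl group with no ring gives a 5.5-fold lower number from compound 2 to compound 4 (0.74 log units; beyond the scatter), while the comparisons with the two hydroxyphenyl esters give a 1.7-fold lower number from compound 3 to compound 4 (0.23 log units; within the scatter) and a 1.6-fold lower number from compound 1 to compound 4 (0.21 log units; within the scatter). In this assay the butyl, 2-hydroxyphenyl and 4-hydroxyphenyl groups therefore cannot be told apart, and among these four compounds only the 1-methyl-1H-pyrazol-5-yl group stands clear of the others, with its steps to all three beyond the scatter. An aromatic ring as such does not separate the compounds, as the two hydroxyphenyl esters and the butyl ester fall together, so the higher number goes with the 1-methyl-1H-pyrazol-5-yl group in this set and not with aromatic groups in general.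

Nothing measured here accounts for the standing of the 1-methyl-1H-pyrazol-5-yl group. On these data alone, it remains open whether a longer chain, a carboxylic acid, an amine or a pyrazole without the methyl group at this carbonyl carbon would stay with compound 4 or come closer to compound 2.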